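Methoxy addition on two cytotoxic chromone-type cores

This account rests on a few compounds, and the source may have more. Where it says the series, first, only, none or still open, it means among the compounds named here.

Compound 1 `COC1(c2ccccc2)Oc2ccccc2C(=O)C1(O)O` gives 19 ug/mL in a functional assay on KB cells (Homo sapiens) for cytotoxicity; a higher number here means that more compound is needed for the effect, a lower number that less compound is needed.
Compound 2 `COc1ccc(OC)c(-c2cc(=O)c3c(OC)c(OC)c(OC)c(OC)c3o2)c1` gives 4 ug/mL in this assay.
Compound 3 `COc1cc(OC)c(-c2cc(=O)c3c(OC)c(OC)c(OC)c(OC)c3o2)cc1OC` gives 13 ug/mL in this assay.

Compound 2 and compound 3 share one core; the change between them is methoxy in place of hydrogen on an aromatic carbon and it gave a 3.3-fold higher number from compound 2 to compound 3 (0.51 log units; beyond the scatter). Compound 1 has a different core; the difference between the two cores is not broken down here. Compound 4 `COc1ccc2c(c1)OC(OC)(c1ccccc1)C(O)(O)C2=O` arises from compound 1 by methoxy in place of hydrogen on an aromatic carbon. This is the same kind of change, not the same: in compound 3 the entering group sits ortho to a methoxy group, meta to a methoxy group and para to a large group, whereas in compound 4 it sits on a ring that is part of a fused or bridged system of two rings, meta to a fused ring and para to a fused ring. Compound 4 is expected to show a 2.4-fold higher number from compound 1 to compound 4 (0.37 log units; beyond the scatter) in this assay; this rests only on a 3.3-fold higher number from compound 2 to compound 3 (0.51 log units; beyond the scatter), with the core and surroundings differing. Compound 4 is estimated at 45 ug/mL, between 18 ug/mL and 110 ug/mL.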

Compound 4, concentration for half-maximal effect: 20 ug/mL
Estimate against measurement, compound 4: 2.3-fold (0.35 log units) above, and the stated range covers the measured number.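

In this assay methoxy in place of hydrogen on an aromatic carbon gives a 1.1-fold higher number from compound 1 to compound 4 (0.02 log units; within the scatter) and so no readable change on this core. The step seen on the other core therefore does not carry over in size to this one: the same change on two cores in this assay, a 3.3-fold higher number (0.51 log units; beyond the scatter) from compound 2 to compound 3 and a 1.1-fold higher number (0.02 log units; within the scatter) from compound 1 to compound 4, 3.1-fold (0.49 log units) apart, beyond the scatter of two such steps. This rests on one pair per core, with the methoxy entering different surroundings in each, so it shows that the step cannot be transferred as a fixed amount here but does not show what separates the two cores.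

Open, as far as these compounds go, is whether an amine or a carboxylic acid in place of the same hydrogen would move the number on the core of compound 1. Also open, from the compounds shown here alone, is whether methoxy on the unfused phenyl ring of compound 1 would do so.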